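Swapping nitro for fluoro on a sulfonamide prostanoid core

The source may report more compounds than this note shows. Statements on the series, on what has been measured and on what is new or still open speak of the compounds shown alone.

Measured compounds:
- Compound 1, `O=C(O)CCC/C=C\C[C@H]1[C@@H]2CCC(C2)[C@@H]1NS(=O)(=O)c1ccc([N+](=O)[O-])cc1`, in a functional assay (plasma) for inhibition, with Oryctolagus cuniculus as the target (a lower number here means a stronger inhibitor, a higher number a weaker inhibitor), compound 1 gives 1400 nM.
- Compound 2, `CCc1ccc(S(=O)(=O)N[C@H]2C3CC[C@H](C3)[C@@H]2C/C=C\CCCC(=O)O)cc1`, in this assay compound 2 gives 4600 nM.

Going by the values given here, compound 1 holds the lower of the two numbers seen so far; the only other measured compound, compound 2, stands one step away, and the step of a 3.3-fold higher number from compound 1 to compound 2 (0.52 log units; beyond the scatter) means that ethyl in place of nitro on an aromatic carbon weakened inhibition modestly, more than the scatter of repeated measurements.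

Compound 3, `O=C(O)CCC/C=C\C[C@H]1[C@@H]2CCC(C2)[C@@H]1NS(=O)(=O)c1ccc(F)cc1`, has not yet been measured. It differs from compound 1 by fluoro in place of nitro on an aromatic carbon. Among the compounds with values here, the single step that bears on it is the one from compound 1 to compound 2, in which the nitro group was also removed from the same aromatic carbon and something else put in its place; that step cost inhibition modestly, as a 3.3-fold higher number from compound 1 to compound 2 (0.52 log units; beyond the scatter) shows. Within the data shown here, with only this one comparison in hand, a loss of similar size is the most reasonable expectation when nitro gives way to fluoro, though the true step could be smaller and fall within the scatter.

Compound 3 is therefore expected to give 3000 nM in this assay, with a likely range from 1200 nM to 8000 nM, a step estimated as a 2.1-fold higher number from compound 1 to compound 3 (0.33 log units; beyond the scatter).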

Compound 3, half-maximal inhibitory concentration: 600 nM
For compound 3 the middle estimate is 5.0-fold (0.70 log units) above the measured one; the measured number lies below the stated range.
By their numbers in this assay, from the lowest: compound 3; then compound 1; then compound 2.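

Removing nitro from this aromatic carbon does not by itself weaken inhibition in this assay, since fluoro in its place gives a 2.3-fold lower number from compound 1 to compound 3 (0.37 log units; beyond the scatter) and so reverses the direction seen earlier with ethyl. What matters here is therefore which group replaces nitro and not only the loss of nitro, and the two replacements lie well apart, with fluoro in place of ethyl giving a 7.7-fold lower number from compound 2 to compound 3 (0.88 log units; beyond the scatter) on the same carbon. No measurement at hand offers a reason for this order among the three groups.

On these data alone, how a chloro, a methoxy or an amine on this carbon would compare remains open, as does the plain ring with only a hydrogen there, and three groups are too few to show a trend that would predict them. All three compounds also share one core and one substituted ring position, so whether fluoro in place of nitro would give a similar step on another core, or elsewhere on the ring, cannot be told from them.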